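The compounds below may be only part of what the source reports. "The series", "measured", "known", "first", "only" and "open" are said of these compounds alone.

Compounds measured so far:
Compound 1 `COc1cc(OC)cc(N2CCN(C(=O)c3oc(C)nc3-c3cccc(F)c3)CC2)c1` — in a functional assay on HL-60 cells (Homo sapiens) for inhibition, read by MTT assay, with a stated time of 72 h (on this read-out higher numbers stand for weaker inhibition and lower numbers for stronger inhibition), compound 1 gives 28.2 nM.
Compound 2 `Cc1nc(-c2cccc(F)c2)c(C(=O)N2CCN(c3cc(Cl)cc(Cl)c3)CC2)o1` — in this assay compound 2 gives 41.7 nM.
Compound 3 `Cc1nc(-c2cccc(F)c2)c(C(=O)N2CCN(c3cccc(Cl)c3)CC2)o1` — in this assay compound 3 gives 33.7 nM.

Compound 1 has the lowest number of the three, but it is not separated from the others: the step of a 1.5-fold higher number from compound 1 to compound 2 (0.17 log units; within the scatter) and the step of a 1.2-fold higher number from compound 1 to compound 3 (0.08 log units; within the scatter) both lie within the scatter, as does the step of a 1.2-fold lower number from compound 2 to compound 3 (0.09 log units; within the scatter). All three measured steps alter only the aryl group on the amine nitrogen in the ring, and none of them moves the number beyond the scatter.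

Compound 4 `COc1cc(OC)cc(N2CCN(C(=O)c3oc(C)nc3-c3ccccc3)CC2)c1` differs from compound 1 elsewhere: hydrogen in place of fluoro on an aromatic carbon. Going by the values given here, no measured step touches this aromatic carbon, so there is no direct precedent for the change. The measured steps show that this series tolerates substituent changes on an aryl ring without a shift beyond the scatter, and the removal of a single fluorine is a small change. Compound 4 is therefore expected to give a step of about a 1.1-fold higher number from compound 1 to compound 4 (0.05 log units; within the scatter), with no change beyond the scatter in either direction. Compound 4 is estimated at 32 nM, in the range 14 nM to 70 nM.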

Compound 4, half-maximal inhibitory concentration: 19.2 nM
The estimate for compound 4 lay 1.7-fold (0.22 log units) above the measured number; the range from low to high includes it.
By their numbers in this assay, from the lowest: compounds 4, 1, 3 and 2 (each within the scatter of the next, the first and the last beyond it).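

In this assay, going by these compounds alone, the change from 3-fluorophenyl to phenyl gives the first measured step at this aromatic carbon: a 1.5-fold lower number from compound 1 to compound 4 (0.17 log units; within the scatter). Within the data shown here, the fluoro group can therefore be replaced by hydrogen on the core of compound 1 without the number moving beyond the scatter, so this position joins the aryl group on the amine nitrogen in the ring as a place where no measured step exceeds the scatter. Nothing measured here bears on the reason for the size of this step.

The compounds shown carry only fluoro or hydrogen at this aromatic carbon, so the outcome with a nitrile, a trifluoromethyl group or an amine there remains open. Also open, going by these compounds, is whether the same exchange of fluoro for hydrogen would stay within the scatter alongside the 3-chlorophenyl group of compound 3 or the 3,5-dichlorophenyl group of compound 2.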